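The source may report more compounds than this note shows. Statements on the series, on what has been measured and on what is new or still open speak of the compounds shown alone.

Compound 1, `Cc1ccnc(/C(N)=N/NC(=S)N2CCSCC2)c1`: in a functional assay on HeLa cells (Homo sapiens) for cytotoxicity, read by MTT assay, with a stated time of 72 h, tested at 3 uM (a lower number here means less inhibition of growth, a higher number more inhibition of growth at the concentration tested), compound 1 gives 40.4%.
Compound 2, `Cc1cccc(/C(N)=N/NC(=S)N2CCCCC2)n1`: in this assay compound 2 gives 68.9%.
Compound 3, `N/C(=N\NC(=S)N1CCN(c2ccccn2)CC1)c1ccc(F)cn1`: in this assay compound 3 gives 77.3%.

Among these three, compound 3 shows the highest number, yet the number of compound 2 lies within the usual scatter of it, so the two cannot be set in order; only compound 1 lies clearly beyond the scatter, at a lower number. Compound 4, `Cc1cccc(/C(N)=N/NC(=S)N2CCN(c3ccccn3)CC2)n1`, has not yet been measured. It differs from compound 3 in one place: 6-methylpyridin-2-yl in place of 5-fluoropyridin-2-yl on a carbon with a double bond to nitrogen. The rest of the molecule, including the thiourea and the pyridylpiperazine part, is kept.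

The 6-methylpyridin-2-yl group that enters is the same group found in compound 2, which on a different thiourea partner gave a number close to that of compound 3. On that ground the step from compound 3 to compound 4 in this assay is expected to be small, most likely within the scatter, if anything slightly downward; the expected change is a number 6.3 percentage points lower from compound 3 to compound 4 (within the scatter). Compound 4 is therefore estimated to give 71%, with a range from 56% to 84%.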

Compound 4, percent growth inhibition at one concentration: 72.7%
For compound 4 the middle estimate is 1.7 percentage points below the measured one; measured number inside the range.
By their numbers in this assay, from the lowest: compound 1; then compounds 2, 4 and 3 (each within the scatter of the next).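

Among these compounds, compound 3 and compound 4 form the first pair in the set that differs in one place, with the thiourea and the pyridylpiperazine part kept, so the group on a carbon with a double bond to nitrogen can be read on its own. In this assay, among the compounds shown here, the exchange gives a number 4.6 percentage points lower from compound 3 to compound 4 (within the scatter), which means that 6-methylpyridin-2-yl and 5-fluoropyridin-2-yl cannot be told apart at this place on this partner, something the earlier compounds, which differ in more than one place, could not show. Nothing available explains this outcome, and no reason for it can be given from the data.

Going by these compounds, the two groups compared are both substituted pyridin-2-yl rings, so it remains open whether a plain phenyl ring, an unsubstituted pyridin-2-yl or a 6-aminopyridin-2-yl group at this place would also stay within the scatter of compound 3. On these data alone, it also remains open whether the same exchange would give so small a step on another thiourea partner, such as the piperidine of compound 2 or the thiomorpholine of compound 1, or at other concentrations in this assay.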